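The source may report more compounds than this note shows. Statements on the series, on what has been measured and on what is new or still open speak of the compounds shown alone.

In a functional assay on MCF7 cells (Homo sapiens) for antiproliferative activity, read by MTT assay (a higher number here means a weaker inhibitor, a lower number a stronger inhibitor), compound 1 (`COc1ccc(-c2ccnc(Nc3ccc([N+](=O)[O-])cc3)n2)cc1`) gives 770 nM and compound 2 (`Clc1ccc(Nc2nccc(-c3ccc(Br)cc3)n2)cc1`) gives 4180 nM as the higher of the two numbers, with a gap beyond the scatter. Compound 3 (`COc1ccc(-c2ccnc(Nc3ccc(Cl)cc3)n2)cc1`) departs from compound 2 in one place (methoxy in place of bromo on an aromatic carbon): methoxy in place of bromo on an aromatic carbon, para to a large group. For the measured compounds named here, no measured pair isolates this change, so the evidence for its size is thin. Compound 1 at 770 nM also carries methoxy, and on that single value a lower number is expected for compound 3 in this assay as a moderate move, not a large one. The expected step runs a 2.3-fold lower number from compound 2 to compound 3 (0.37 log units; beyond the scatter) and would point towards stronger inhibition. Compound 3 is estimated at 1800 nM (expected range 600 nM to 5000 nM).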

Compound 3, half-maximal inhibitory concentration: 810 nM
Compound 3: the middle estimate sits 2.2-fold (0.35 log units) above what was measured; low and high end bracket the measured number.
By their numbers in this assay, from the lowest: compounds 1 and 3 (each within the scatter of the next); then compound 2.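

In this assay, for the compounds shown here, the methoxy-for-bromo change, para to a large group, gives a 5.2-fold lower number from compound 2 to compound 3 (0.71 log units; beyond the scatter) and is the first single-place reading at this position, where the earlier pair differed in two places. With methoxy held fixed, chloro in place of nitro on the other aromatic ring gives a 1.1-fold higher number from compound 1 to compound 3 (0.02 log units; within the scatter) and so leaves no reading of a change at that site. Nothing measured here accounts for the methoxy step.

As far as these compounds go, it remains open whether this step belongs to methoxy itself or would also appear with a hydroxyl group, an amine or a longer ether such as ethoxy at the same place. From the compounds shown here alone, it is also open whether chloro and nitro would still match with bromo in place of methoxy, or whether an amine or a carboxylic acid at their site would read differently.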